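This account rests on a few compounds, and the source may have more. Where it says the series, first, only, none or still open, it means among the compounds named here.

Measured so far: compound 1 `Cc1ccc(COc2cc([N+](=O)[O-])ccc2NS(C)(=O)=O)cc1`, 1750 nM; compound 2 `CS(=O)(=O)Nc1ccc([N+](=O)[O-])cc1OCc1ccc(Cl)cc1`, 290 nM; compound 3 `CN(c1ccc([N+](=O)[O-])cc1OCc1ccc(Cl)cc1)S(C)(=O)=O`, 2400 nM in an assay on SK-BR-3 cells for inhibition of Aromatase (Homo sapiens); on this read-out higher numbers stand for weaker inhibition and lower numbers for stronger inhibition.

Compound 3 gives the highest of the three numbers; compound 1 sits within the scatter of it, while compound 2 lies an 8.3-fold higher number from compound 2 to compound 3 (0.92 log units; beyond the scatter). The step to compound 4 `CN(c1ccc([N+](=O)[O-])cc1OCc1ccc(Br)cc1)S(C)(=O)=O` is bromo in place of chloro on an aromatic carbon. Within the data shown here, no measured step swaps one halogen for another; the only change at that place is a 6.0-fold lower number from compound 1 to compound 2 (0.78 log units; beyond the scatter), which involves a different group and bears on it only loosely. Compound 4 is therefore expected to give 2000 nM, between 800 nM and 5000 nM, a step of a 1.2-fold lower number from compound 3 to compound 4 (0.08 log units; within the scatter), which is not expected to go beyond the scatter.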

Compound 4, half-maximal inhibitory concentration: 330 nM
Compound 4: the middle estimate sits 6.1-fold (0.78 log units) above what was measured, and the stated range ends above it.
By their numbers in this assay, from the lowest: compounds 2 and 4 (each within the scatter of the next); then compounds 1 and 3 (each within the scatter of the next).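

Exchanging one halogen for another on an aromatic carbon para to a large group is not a neutral swap: this assay records a 7.3-fold lower number from compound 3 to compound 4 (0.86 log units; beyond the scatter), a step of modest size for a change of a single heavy atom. Among these compounds, this is the first step that keeps a halogen at this place, and it shows that the identity of the halogen alone moves the number beyond the scatter. No evidence available here accounts for this step.

On these data alone, whether bromo has the same effect with a hydrogen on the sulfonamide nitrogen remains open. So does what fluoro, iodo, methoxy or a carboxylic acid would give at this place.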